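The source may hold more compounds than are shown below. What is called first, only, known or untested is meant among the compounds shown, and "the series" means these compounds.

Measured so far:
Compound 1, `Cc1c([C@H](C)Nc2nc(N)nc(N)c2C#N)c(-c2ccccc2)c(=O)n2cc(F)ccc12`: in an ADME assay on microsomes from liver (Homo sapiens), read by LC-MS, using NADPH, with a stated time of 30 min, tested at 1 uM (on this read-out higher numbers stand for a more stable compound and lower numbers for a less stable compound), compound 1 gives 80%.
Compound 2, `C[C@H](Nc1nc(N)nc(N)c1C#N)c1c(-c2ccccc2)c(=O)n2cc(F)ccc2c1C1CC1`: in this assay compound 2 gives 91%.

Among the measured compounds shown here, compound 2 stands highest of the two numbers in this assay; the nearest is compound 1, and the single measured step, a number 11 percentage points higher from compound 1 to compound 2 (beyond the scatter), lies beyond the scatter and separates them. Compound 3, `C[C@H](Nc1nc(N)nc(N)c1C#N)c1c(-c2ccccc2)c(=O)n2cc(F)ccc2c1-c1ccc(F)cc1`, has not yet been measured. It differs from compound 2 in one place: 4-fluorophenyl in place of cyclopropyl on an aromatic carbon.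

For the measured compounds named here, only one measured step bears on this change. It is the step at the same aromatic carbon, a number 11 percentage points higher from compound 1 to compound 2 (beyond the scatter), which swapped a methyl for a cyclopropyl and gave a modest rise. Going by the values given here, the present change replaces that cyclopropyl with a 4-fluorophenyl, and no measured pair shows what an aromatic ring at this position does in this assay, so the direction of the step cannot be read from the data. The step from compound 2 to compound 3 is therefore expected to be small or within the scatter, a number 9 percentage points lower from compound 2 to compound 3 (within the scatter). For compound 3 the estimate in this assay is 82%, with a range from 65% to 95%.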

Compound 3, percent of the compound remaining: 87%
Compound 3: the middle estimate sits 5 percentage points below what was measured; low and high end bracket the measured number.
By their numbers in this assay, from the lowest: compounds 1, 3 and 2 (each within the scatter of the next, the first and the last beyond it).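

With 4-fluorophenyl in place of cyclopropyl on this aromatic carbon, ortho to a fused ring, the series now holds an aromatic ring at this position, and this assay does not separate the two groups, with a number 4 percentage points lower from compound 2 to compound 3 (within the scatter) as the step. Set against the methyl group of the core of compound 1, the same 4-fluorophenyl group gives a number 7 percentage points higher from compound 1 to compound 3 (within the scatter) as its step, so compound 3 lies within the scatter of both other compounds, and only the pair of compound 1 and compound 2 stands apart beyond it; a group of 7 heavy atoms at this place thus reads no differently in this stability measure from either the cyclopropyl or the methyl group. No measurement at hand offers an explanation for how closely these three groups read.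

The compounds shown leave open whether the fluorine matters at all, as no plain phenyl group stands beside the 4-fluorophenyl group at this position. They also leave open what a pyridyl ring, an amine or a longer alkyl chain on this aromatic carbon would give in this assay and whether the pattern would hold for them.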